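Adding a Methoxy Group: One Change on Two Different Cores

This account rests on a few compounds, and the source may have more. Where it says the series, first, only, none or still open, it means among the compounds named here.

Measured compounds in a functional assay on L1210 cells (Mus musculus) for antiproliferative activity, with a stated time of 48 h; on this read-out higher numbers stand for weaker inhibition and lower numbers for stronger inhibition:
- compound 1 `C=C(Br)C(=O)Nc1ccc(C(=O)/C=C/c2ccc(OC)c(OC)c2)cc1` gives 1300 nM
- compound 2 `C=C(Br)C(=O)Nc1ccc(C(=O)/C=C/c2cc(OC)c(OC)c(OC)c2)cc1` gives 1500 nM
- compound 3 `COc1ccccc1/C=C/C(=O)c1ccc(N)cc1` gives 12000 nM

Compound 1 and compound 2 share a core and differ in one place: methoxy in place of hydrogen on an aromatic carbon. That change gave a 1.2-fold higher number from compound 1 to compound 2 (0.06 log units; within the scatter), so the extra methoxy left the result essentially where it was.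

Compound 3 sits on a different core, and the difference between the two cores is not broken down here. Its number in this assay is the highest of the three, eight-odd steps beyond the scatter away from both compound 1 and compound 2.

Compound 4 `COc1ccc(/C=C/C(=O)c2ccc(N)cc2)c(OC)c1` is the not yet measured partner of compound 3. It differs from compound 3 by the same kind of change seen between compound 1 and compound 2: methoxy in place of hydrogen on an aromatic carbon. The surroundings are not identical, though. In compound 2 the entering group sits ortho to a methoxy group, meta to a large group and meta to a methoxy group, whereas in compound 4 it sits meta to a methoxy group and para to a large group.

On the evidence of the step from compound 1 to compound 2, which is a 1.2-fold higher number from compound 1 to compound 2 (0.06 log units; within the scatter), the expected step from compound 3 to compound 4 in this assay is a 1.2-fold lower number from compound 3 to compound 4 (0.08 log units; within the scatter), small and within the scatter. Compound 4 is therefore estimated at 10000 nM, with a range of 4000 nM to 30000 nM that allows for the different surroundings and the different core.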

Compound 4, half-maximal inhibitory concentration: 34000 nM
Compound 4: the middle estimate sits 3.4-fold (0.53 log units) below what was measured; measured number outside the range, above it.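

On the core of compound 3, putting a methoxy group in place of a hydrogen on an aromatic carbon weakened inhibition modestly in this assay, giving a 2.8-fold higher number from compound 3 to compound 4 (0.45 log units; beyond the scatter), whereas the same kind of change on the other core gave a 1.2-fold higher number from compound 1 to compound 2 (0.06 log units; within the scatter). Read alone, these steps might suggest that the methoxy matters on one core and not on the other, but setting them side by side does not support a real difference between them: the same change on two cores in this assay, a 1.2-fold higher number (0.06 log units; within the scatter) from compound 1 to compound 2 and a 2.8-fold higher number (0.45 log units; beyond the scatter) from compound 3 to compound 4, 2.5-fold (0.39 log units) apart, within the scatter of two such steps. This shows only that the two results are compatible with a single small effect of the change; it does not show that the effect is the same on both cores, since two pairs are few, and the entering group also sits in different surroundings in each pair, so neither the core nor the ring position can be singled out as the source of the gap.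

The compounds shown leave open how a hydroxy group or a fluorine atom would compare with methoxy at the place it occupies in compound 4, meta to a methoxy group and para to a large group. They also leave open whether that same methoxy pattern would give a similar step on the core of compound 1, which would separate the role of the core from that of the position.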